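Benzyl ether halogen variation, weakest member extended

The source may report more compounds than this note shows. Statements on the series, on what has been measured and on what is new or still open speak of the compounds shown alone.

Measured so far:
compound 1 `Cc1cc(C(=O)O)nn1Cc1cc(Br)ccc1OCc1ccc(Cl)cc1Cl` — 0.49 nM
compound 2 `Cc1cc(C(=O)O)nn1Cc1cc(Br)ccc1OCc1ccc(F)cc1F` — 2.63 nM
compound 3 `Cc1cc(C(=O)O)nn1Cc1cc(Br)ccc1OCc1ccc(Cl)cc1` — 8.71 nM

In a functional assay on CHO-K1 cells for antagonist activity at prostaglandin E2 receptor EP1 subtype (Homo sapiens), read by FLIPR (a lower number here means a stronger inhibitor, a higher number a weaker inhibitor), compound 3 gives 8.71 nM, the highest of the three numbers. The steps leading to it are both beyond the scatter: a 3.3-fold higher number from compound 2 to compound 3 (0.52 log units; beyond the scatter) and an 18-fold higher number from compound 1 to compound 3 (1.25 log units; beyond the scatter). Compound 4 `Cc1cc(C(=O)O)nn1Cc1cc(Br)ccc1OCc1ccc(C(F)(F)F)cc1` differs from compound 3 by trifluoromethyl in place of chloro on an aromatic carbon. Going by the values given here, no measured step exchanges one group for another on that carbon alone; a 5.4-fold higher number from compound 1 to compound 2 (0.73 log units; beyond the scatter) changes two halogens at once, and an 18-fold higher number from compound 1 to compound 3 (1.25 log units; beyond the scatter) removes a group rather than replacing it. Neither bears directly on a trifluoromethyl entering, so in this assay only a small step, if any beyond the scatter, is expected, with the direction open. Compound 4 is therefore estimated at 7 nM (range 2 nM to 25 nM), an expected step of a 1.2-fold lower number from compound 3 to compound 4 (0.09 log units; within the scatter).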

Compound 4, inhibition constant: 97.7 nM
For compound 4 the middle estimate is 14-fold (1.14 log units) below the measured one; measured number outside the range, above it.
By their numbers in this assay, from the lowest: compound 1; then compound 2; then compound 3; then compound 4.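

In this assay, going by these compounds alone, this carbon does not accept trifluoromethyl as a stand-in for chloro: the exchange gives an 11-fold higher number from compound 3 to compound 4 (1.05 log units; beyond the scatter) and is the first measured step that swaps one group for another here alone. The entering group has four heavy atoms against one for chloro, and the shift is large. No available evidence bears on the reason for this step.

Still open, on these data alone, is how a methoxy, a nitrile or an amine on this carbon would compare with chloro and trifluoromethyl. Also open, as far as these compounds go, is whether the further chloro of compound 1 would give a similar gain alongside trifluoromethyl.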